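Three sulfonamides at the assay limit, and a hydroxy analogue

The compounds below may be only part of what the source reports. "The series", "measured", "known", "first", "only" and "open" are said of these compounds alone.

Compound 1, `O=S(=O)(Nc1ccc(-c2nc3ccccc3o2)cc1)c1ccccc1Cl`: in an assay on isolated protein for inhibition of malate dehydrogenase, mitochondrial (Sus scrofa), with stated times of 45 min and 30 min (on this read-out higher numbers stand for weaker inhibition and lower numbers for stronger inhibition), compound 1 gives > 63000 nM, a limit of the assay.
Compound 2, `CS(=O)(=O)Nc1ccc(-c2nc3ccccc3o2)cc1`: in this assay compound 2 gives > 63000 nM, again a limit.
Compound 3, `O=S(=O)(Nc1ccc(-c2nc3ccccc3o2)cc1)c1ccccc1F`: in this assay compound 3 gives > 63000 nM, again a limit.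

Compound 3 stands where every measured compound of this set stands, at the limit of > 63000 nM in this assay, at which 3 of the 3 values shown sit. None of the three values is a number, so none of the three steps between them can be read: a step that the two limits leave unreadable from compound 1 to compound 2, a step that the two limits leave unreadable from compound 1 to compound 3 and a step that the two limits leave unreadable from compound 2 to compound 3 are all left open by the limits on both sides.

Compound 4, `O=S(=O)(Nc1ccc(-c2nc3ccccc3o2)cc1)c1ccccc1O`, is the next compound in this assay. It differs from compound 3 in one place: hydroxy in place of fluoro on an aromatic carbon. Within the data shown here, the only steps that bear on this change are the three unreadable ones above, so they give no size and no direction to expect. What they do show is that three different groups on the sulfonyl sulfur, methyl, 2-chlorophenyl and 2-fluorophenyl, all left the compounds at the limit. On that basis compound 4 is expected to remain at or near that limit as well, with an estimated value of 63000 nM, somewhere between 20000 nM and 200000 nM. The step from compound 3 to compound 4 is therefore expected to be a number no higher from compound 3 to compound 4 (the limit leaves the size open), most likely not readable at all.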

Compound 4, half-maximal inhibitory concentration: > 63000 nM
Compound 4: no number, only a limit; the forecaster's own chance of this, stated with the estimate: 80%; the middle value lies on the limit itself.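

With compound 4 also at a limit in this assay, none of its steps from compound 1, compound 2 or compound 3 can be read. The compounds shown leave open whether methyl, 2-chlorophenyl, 2-fluorophenyl and 2-hydroxyphenyl on the sulfonyl sulfur differ at all in this assay.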